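Quinolin-3-yl replaces 1H-indol-6-yl on an amine nitrogen

The source may report more compounds than this note shows. Statements on the series, on what has been measured and on what is new or still open speak of the compounds shown alone.

In a functional assay on MCF7 cells (Homo sapiens) for cytotoxicity, read by MTT assay, with a stated time of 48 h (a higher number here means a weaker inhibitor, a lower number a stronger inhibitor), compound 1 (`COc1ccc(-c2nc3ccccn3c2C(=O)/C=C\Nc2cc(OC)cc(OC)c2)cc1`) gives 14900 nM and compound 2 (`COc1ccc(-c2nc3ccccn3c2C(=O)/C=C\Nc2ccc3cc[nH]c3c2)cc1`) gives 19400 nM so the two stand within the scatter of each other. Compound 3 (`COc1ccc(-c2nc3ccccn3c2C(=O)/C=C\Nc2cnc3ccccc3c2)cc1`) differs from compound 2 at one place (quinolin-3-yl in place of 1H-indol-6-yl on an amine nitrogen) with quinolin-3-yl in place of 1H-indol-6-yl on an amine nitrogen. Among the compounds with values here, the only measured step at that nitrogen (a 1.3-fold higher number from compound 1 to compound 2 (0.11 log units; within the scatter)) stayed within the scatter, so no step beyond it is expected in this assay here. The estimated step (a 1.1-fold lower number from compound 2 to compound 3 (0.06 log units; within the scatter)) is expected to remain within the scatter. Compound 3 is expected at 17000 nM with 8000 nM to 36000 nM as its estimated range.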

Compound 3, half-maximal inhibitory concentration: 15000 nM
For compound 3 the middle estimate is 1.1-fold (0.05 log units) above the measured one; measured number inside the range.
By their numbers in this assay, from the lowest: compounds 1, 3 and 2 (each within the scatter of the next).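

In this assay the quinolin-3-yl group on the amine nitrogen gives a 1.3-fold lower number from compound 2 to compound 3 (0.11 log units; within the scatter) and a 1.0-fold higher number from compound 1 to compound 3 (0.00 log units; within the scatter) and so stands level with both earlier groups. Trading the hydrogen-bond donor of 1H-indol-6-yl for the hydrogen-bond acceptor of quinolin-3-yl thus brings no step beyond the scatter in this assay. No measurement bears on why these three groups read alike. On these data alone, all three groups on this nitrogen are aromatic, so it stays open whether a cyclohexyl or a benzyl group there would read differently.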